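The source may hold more compounds than are shown below. What is called first, only, known or untested is meant among the compounds shown, and "the series" means these compounds.

Compound 1 `COc1ccc(-c2cc(/C=C/C(=O)c3ccc(N)cc3)[nH]n2)cc1` gives -39% in a functional assay on A498 cells (Homo sapiens) for cytotoxicity, read by sulforhodamine B assay, with a stated time of 48 h, tested at 10 uM (a higher number here means a weaker effect of the compound at the concentration tested, a lower number a stronger effect), the lowest of the two numbers available here. Compound 2 `COc1cc(-c2cc(/C=C/C(=O)c3ccc(Cl)c(Cl)c3)[nH]n2)cc(OC)c1OC` gives 43% in this assay, a far higher number, well beyond the scatter. Compound 3 `COc1ccc(-c2cc(/C=C/C(=O)c3ccc(N)cc3)[nH]n2)cc1OC` has not yet been measured; it differs from compound 1 by methoxy in place of hydrogen on an aromatic carbon. For the measured compounds named here, no measured pair shows this particular change, so its size and direction are unknown. Compound 3 is expected to stay close to compound 1, with an expected step of a number 9 percentage points higher from compound 1 to compound 3 (within the scatter) that is not clearly beyond the scatter in either direction. The estimate for compound 3 is -30%, ranging from -70% to 15%.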

Compound 3, a percentage reported as activity, at one concentration (the size of the read-out at that concentration, not a potency): -16%
Compound 3: the middle estimate sits 14 percentage points below what was measured, and the stated range covers the measured number.
By their numbers in this assay, from the lowest: compound 1; then compound 3; then compound 2.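

Methoxy in place of hydrogen on this aromatic carbon, ortho to a methoxy group, gives a number 23 percentage points higher from compound 1 to compound 3 (beyond the scatter) in this assay. For the compounds shown here, this is the first measured step at this position, and it shows that the position responds to substitution: the added group weakens the effect at the concentration tested, though compound 3 still gives -16%. No measurement on hand explains why the number rises. As far as these compounds go, whether a fluorine atom, an ethoxy group or an amine at this carbon would move the number further, or back, remains open, as does whether the step would hold elsewhere on the shared core.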